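A few compounds are considered here, and "the series" means these few. Any claim that something is new, unique, unknown or untested is made for them only; others in the source may bear on it.

Values measured in an ADME assay on HEK-293T cells (Homo sapiens) for cytotoxicity, read by luminescence, with a stated time of 24 h; a higher number here means that more compound is tolerated, a lower number that less compound is tolerated:
- compound 1 `CCCNC(=O)C1CCN(C(=O)c2cc3sccc3n2Cc2ccc(OC)cc2)CC1`: 18800 nM
- compound 2 `CCCNCc1cc2c(cc(C(=O)N3CCC(C(=O)NCCC)CC3)n2Cc2ccc(OC)cc2)s1`: > 100000 nM (a limit of the assay, not a number)
- compound 3 `CCCNC(=O)C1CCN(C(=O)c2cc3sc(CNCc4ccccc4)cc3n2Cc2ccc(OC)cc2)CC1`: 46800 nM

Of the two true numbers, the higher belongs to compound 3, at 46800 nM, while compound 1 gives 18800 nM. For compound 2, the reading of > 100000 nM is a limit.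

Compound 4 `CCCNC(=O)C1CCN(C(=O)c2cc3sc(C)cc3n2Cc2ccc(OC)cc2)CC1` comes from compound 3 by one change: hydrogen in place of benzylamino on a saturated chain carbon bound to an aromatic carbon. Hydrogen takes the place of benzylamino on a saturated chain carbon bound to an aromatic carbon, so (benzylamino)methyl becomes methyl.

Among the compounds with values here, two measured steps bear on this change. Putting (benzylamino)methyl in place of hydrogen gave a 2.5-fold higher number from compound 1 to compound 3 (0.40 log units; beyond the scatter). Putting (propylamino)methyl in place of hydrogen gave an at least 5.3-fold higher number from compound 1 to compound 2 (0.72 log units; beyond the scatter). Both added groups raised the number in this assay, and compound 4 keeps only the methyl of that group. Much of the rise seen in a 2.5-fold higher number from compound 1 to compound 3 (0.40 log units; beyond the scatter) is therefore expected to be lost.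

The expected step is a 2.2-fold lower number from compound 3 to compound 4 (0.35 log units; beyond the scatter), a modest move toward a lower number. The estimate for compound 4 is 21000 nM, within an expected range of 9000 nM to 50000 nM.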

Compound 4, half-maximal cytotoxic concentration: 36300 nM
The estimate for compound 4 lay 1.7-fold (0.24 log units) below the measured number, and the stated range covers the measured number.
By their numbers in this assay, from the lowest: compounds 1, 4 and 3 (each within the scatter of the next, the first and the last beyond it). At a limit, above all of these: compound 2.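

In this assay, going from (benzylamino)methyl to methyl leaves no change that can be told from the scatter (a 1.3-fold lower number from compound 3 to compound 4 (0.11 log units; within the scatter)). Methyl in place of hydrogen on an aromatic carbon is also within the scatter (a 1.9-fold higher number from compound 1 to compound 4 (0.29 log units; within the scatter)), so compound 4 cannot be separated from compound 1 or compound 3, even though those two lie beyond the scatter of each other. Going from (propylamino)methyl to methyl does give a step beyond the scatter (an at least 2.7-fold lower number from compound 2 to compound 4 (0.44 log units; beyond the scatter)), but the reading for compound 2 is a limit of the assay and not a number: the limit of > 100000 nM in this assay, at which 1 of the 4 values shown sits.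

The compounds shown leave open whether the amine nitrogen itself matters on this saturated chain carbon, which an ether or a hydroxyl group there could test. They also leave open how a longer chain than propyl on that nitrogen would read.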